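Replacing a pyridine ring with a saturated carbon ring

The source may report more compounds than this note shows. Statements on the series, on what has been measured and on what is new or still open speak of the compounds shown alone.

Two compounds share one core. Compound 1 `O=C(O)c1ccc(NC(c2ccc(Br)cc2)c2ccc3cccnc3c2O)cc1` gives 6700 nM in an assay on isolated protein for inhibition of CAAX prenyl protease 2 (Homo sapiens), with stated times of 60 s and 60 min (a lower number here means a stronger inhibitor, a higher number a weaker inhibitor), and compound 2 `O=C(O)c1ccc(NC(c2ccccn2)c2ccc3cccnc3c2O)cc1` gives 38000 nM in this assay. Among the measured compounds shown here, compound 2 thus has the higher of the two numbers, the weaker inhibition; the only measured step, a 5.7-fold higher number from compound 1 to compound 2 (0.75 log units; beyond the scatter), separates it from compound 1. Compound 3 `O=C(O)c1ccc(NC(c2ccc3cccnc3c2O)C2CCCCC2)cc1` differs from compound 2 by cyclohexyl in place of pyridin-2-yl on a saturated chain carbon bound to an aromatic carbon and a nitrogen on an aromatic ring. For the measured compounds named here, the one measured step bears on this change only loosely: it shows that swapping the group at this saturated chain carbon can move the number beyond the scatter in either direction. Since compound 1 sits well below compound 2, a step back toward compound 1 is expected, so a 2.5-fold lower number from compound 2 to compound 3 (0.40 log units; beyond the scatter) is the estimated move. For compound 3 the expected value in this assay is 15000 nM, within a range from 4000 nM to 50000 nM.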

Compound 3, half-maximal inhibitory concentration: 9800 nM
Beside the measured number, compound 3's estimate is 1.5-fold (0.18 log units) above it, within the range that was stated.
By their numbers in this assay, from the lowest: compounds 1 and 3 (each within the scatter of the next); then compound 2.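

At this saturated chain carbon, an aromatic ring is not required for the level of inhibition seen in this assay: there is a 3.9-fold lower number from compound 2 to compound 3 (0.59 log units; beyond the scatter) when cyclohexyl, a non-aromatic ring of carbon only, enters. Set against 4-bromophenyl, cyclohexyl gives a 1.5-fold higher number from compound 1 to compound 3 (0.17 log units; within the scatter) in this assay, so compound 1 and compound 3 cannot be told apart, and only compound 2 stands apart from the others. Nothing available explains why pyridin-2-yl gives the highest number of the three.

Still open, going by these compounds, is whether a plain phenyl would match 4-bromophenyl, and whether pyridin-3-yl, with its ring nitrogen moved, would behave like pyridin-2-yl. On these data alone, how a non-ring group such as methyl or a longer chain such as hexyl would fare at this carbon also remains unknown.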